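The source may hold more compounds than are shown below. What is called first, only, known or untested is meant among the compounds shown, and "the series" means these compounds.

Two compounds sharing one core have been examined in a functional assay on PC-3M cells (Homo sapiens) for cytotoxicity, read by MTT assay, with a stated time of 48 h; a higher number here means a weaker inhibitor, a lower number a stronger inhibitor. Compound 1, `Cc1nnc(SCC(=O)c2ccc(Cl)cc2)n1N1C(=O)c2ccccc2C1=O`, gives only a limit of that assay rather than a number: in this assay compound 1 shows > 200000 nM. Compound 2, `Cc1nnc(SCC(=O)c2ccccc2)n1N1C(=O)c2ccccc2C1=O`, likewise reaches only a limit: in this assay compound 2 shows > 200000 nM. The step from compound 1 to compound 2, a step that the two limits leave unreadable from compound 1 to compound 2, cannot be sized, because the limit of > 200000 nM in this assay, at which 2 of the 2 values shown sit, covers both ends of it. Compound 2 therefore stands at that limit, with no number of its own.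

Compound 3, `CCCc1nnc(SCC(=O)c2ccccc2)n1N1C(=O)c2ccccc2C1=O`, differs from compound 2 by ethyl in place of hydrogen on a saturated chain carbon bound to an aromatic carbon. Within the data shown here, no measured step of this kind is available; the only measured step, from compound 1 to compound 2, concerns a different change and is itself unreadable. Both values seen so far sit at the limit, so no direction for this change can be read from them, and the expectation is that compound 3 stays where compound 2 stands, with the step of a number no higher from compound 2 to compound 3 (the limit leaves the size open) expected to be none beyond the scatter. In this assay compound 3 is estimated at 200000 nM, within a range from 50000 nM to 400000 nM.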

Compound 3, half-maximal inhibitory concentration: > 200000 nM
Compound 3 was reported as a limit; the forecaster's own chance of this, stated with the estimate: 85%; the middle value lies on the limit itself.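

Compound 3, like compound 2, gives only a limit and no number in this assay, so the step between them cannot be read: the limit of > 200000 nM in this assay, at which 3 of the 3 values shown sit.

The compounds shown leave open whether ethyl in place of hydrogen has any effect at all in this assay, and what number, if any, a compound on the shared core would reach there.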